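The source may hold more compounds than are shown below. What is called first, only, known or untested is meant among the compounds shown, and "the series" means these compounds.

In an assay for inhibition of Tryptophan 2,3-dioxygenase (Homo sapiens), with stated times of 10 min and 60 min, tested at 10 uM (a higher number here means a stronger effect of the compound at the concentration tested, a lower number a weaker effect), compound 2 `O=[N+]([O-])c1cc(OCc2ccccc2)ccc1CNc1cc(C(F)(F)F)cc2[nH]ncc12` gives 49%, the higher of the two numbers recorded, and compound 1 `O=C1NC(=O)c2c(NCc3ccccc3[N+](=O)[O-])cccc21` gives 17%, a gap that lies beyond the scatter of the assay. The structural change leading to compound 3 `O=[N+]([O-])c1cc(Cl)ccc1CNc1cc(C(F)(F)F)cc2[nH]ncc12` is chloro in place of benzyloxy on an aromatic carbon. Among the measured compounds shown here, with no measured step of this kind to lean on, only a modest downward move in this assay is expected from compound 2 to compound 3, since the change removes a large group while leaving the shared core of compound 2 intact. Compound 3 is therefore estimated at 35% in this assay, within a range from 15% to 55%, with the expected step being a number 14 percentage points lower from compound 2 to compound 3 (beyond the scatter).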

Compound 3, a percentage reported as inhibition, at one concentration (the size of the read-out at that concentration, not a potency): 90%
Compound 3: middle estimate off by 55 percentage points, on the low side; the whole stated range lies below it.
By their numbers in this assay, from the lowest: compound 1; then compound 2; then compound 3.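

In this assay, chloro in place of benzyloxy on this aromatic carbon, meta to a nitro group, gives a number 41 percentage points higher from compound 2 to compound 3 (beyond the scatter) and thus a large gain. The position therefore does not need the benzyloxy group or its aromatic ring, and the single chlorine atom reads far better here. Nothing measured on hand accounts for this gain.

From the compounds shown here alone, whether the gain belongs to chloro itself or to the loss of benzyloxy stays open; fluoro, methoxy or plain hydrogen on this carbon would separate the two. Going by these compounds, how an amine or a carboxylic acid would read there also remains open.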